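The compounds below may be only part of what the source reports. "The series", "measured", "known", "first", "only" and "open" are said of these compounds alone.

In a functional assay on HepG2 cells (Homo sapiens) for antiproliferative activity, read by MTT assay, with a stated time of 72 h (on this read-out lower numbers stand for stronger inhibition and higher numbers for weaker inhibition), compound 1 `C=C(Cl)C(=O)Nc1cc(Nc2nccc(-c3cn(C)c4ccccc34)n2)c(OC)cc1N(C)CCN(C)C` gives 1390 nM.
In this assay compound 2 `COc1cc(N(C)CCN(C)C)c(NC(=O)C(Cl)=C(Cl)Cl)cc1Nc1nccc(-c2cn(C)c3ccccc23)n1` reaches only the assay limit, > 50000 nM (the limit of > 50000 nM in this assay, at which 1 of the 3 values shown sits).
In this assay compound 3 `CC/C=C\C(=O)Nc1cc(Nc2nccc(-c3cn(C)c4ccccc34)n2)c(OC)cc1N(C)CCN(C)C` gives 6670 nM.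

Compound 3 holds the higher of the two numbers, with a 4.8-fold higher number from compound 1 to compound 3 (0.68 log units; beyond the scatter) separating it from compound 1, while compound 2 remains a limit. Compound 4 `CCC/C=C\C(=O)Nc1cc(Nc2nccc(-c3cn(C)c4ccccc34)n2)c(OC)cc1N(C)CCN(C)C` differs from compound 3 by methyl in place of hydrogen on a saturated chain carbon, two bonds along the chain from a double-bonded chain carbon. The measured steps, an at least 35-fold higher number from compound 1 to compound 2 (1.55 log units; beyond the scatter) and an at least 7.4-fold lower number from compound 2 to compound 3 (0.87 log units; beyond the scatter), all swap the whole group on the carbonyl carbon, so none tests a single added methyl on the chain. Such a small lengthening is expected to move the number little, so the step of a 1.0-fold lower number from compound 3 to compound 4 (0.01 log units; within the scatter) is estimated to fall within the scatter. Compound 4 is therefore expected to give about 6500 nM, in the range 2500 nM to 17000 nM.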

Compound 4, half-maximal inhibitory concentration: 431 nM
Compound 4: the middle estimate sits 15-fold (1.18 log units) above what was measured, and the stated range ends above it.
By their numbers in this assay, from the lowest: compound 4; then compound 1; then compound 3. At a limit, above all of these: compound 2.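

Adding one methyl to the chain, which turns but-1-en-1-yl into pent-1-en-1-yl, gives a 15-fold lower number from compound 3 to compound 4 (1.19 log units; beyond the scatter), so the number at this position responds strongly to chain length, which the earlier swaps of the whole group could not show. The pent-1-en-1-yl compound also outdoes the 1-chloroethenyl compound, with a 3.2-fold lower number from compound 1 to compound 4 (0.51 log units; beyond the scatter). Against compound 2 the gap is only a minimum, an at least 110-fold lower number from compound 2 to compound 4 (2.06 log units; beyond the scatter), and compound 2 is a limit: the limit of > 50000 nM in this assay, at which 1 of the 4 values shown sits.

Only one lengthening step is shown, so whether a longer chain such as hexenyl lowers the number further remains open. On these data alone, the effect of an amine at the chain end is also open.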